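Replacing One Aromatic Group on a Bromo Compound

The compounds below may be only part of what the source reports. "The series", "measured", "known", "first", "only" and "open" are said of these compounds alone.

In a functional assay on MCF7 cells (Homo sapiens) for cytotoxicity, read by MTT assay and propidium iodide staining, with a stated time of 24 h (a higher number here means a weaker inhibitor, a lower number a stronger inhibitor), compound 2 `Cc1ccc(-c2nnc(SCC(=O)c3ccc(Br)cc3)o2)c(O)c1` gives 2070 nM and sits level with compound 3 `CC(C)(C)c1ccc(-c2nnc(SCC(=O)c3ccc(Br)cc3)o2)cc1` at 1950 nM within the scatter, while compound 1 `Cc1ccc(-c2nnc(SCC(=O)c3ccccc3)o2)c(O)c1` stands apart at 150 nM on these numbers. Among the measured compounds shown here, the one measured step, bromo in place of hydrogen on an aromatic carbon, is large, with a 14-fold higher number from compound 1 to compound 2 (1.14 log units; beyond the scatter) here, but it does not touch the group that changes next. Compound 4 `O=C(CSc1nnc(-c2ccccc2F)o1)c1ccc(Br)cc1` keeps the bromo and has 2-fluorophenyl in place of 2-hydroxy-4-methylphenyl on an aromatic carbon. Compound 3 also pairs the bromo with another group at that place, and its 1950 nM in this assay matches compound 2 within the scatter. The expected step is therefore a 1.0-fold lower number from compound 2 to compound 4 (0.01 log units; within the scatter) and nothing beyond the scatter. The estimated value for compound 4 is 2000 nM (expected range 800 nM to 5000 nM).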

Compound 4, half-maximal inhibitory concentration: 240 nM
The estimate for compound 4 lay 8.3-fold (0.92 log units) above the measured number; measured number outside the range, below it.
By their numbers in this assay, from the lowest: compounds 1 and 4 (each within the scatter of the next); then compounds 3 and 2 (each within the scatter of the next).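

With the bromo kept, this position proves sensitive to what it carries: in this assay the change to 2-fluorophenyl gives an 8.6-fold lower number from compound 2 to compound 4 (0.94 log units; beyond the scatter) and so a stronger inhibitor. Not every group there does this, since compound 3 gives 1950 nM and stays level with compound 2. No measurement available here explains the step. The change also removes the hydroxy and methyl groups and adds the fluorine together, so their separate contributions remain unresolved. Going by these compounds, it remains open how an amine or a methoxy group on this aromatic ring would compare.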